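Adding a Methoxy Group on Cytotoxic Chalcone-Pyrazoles

The source may report more compounds than this note shows. Statements on the series, on what has been measured and on what is new or still open speak of the compounds shown alone.

Of the compounds shown here, three have been measured in a functional assay on BT-549 cells (Homo sapiens) for cytotoxicity, read by sulforhodamine B assay, with a stated time of 48 h, tested at 10 uM (a lower number here means a stronger effect, a higher number a weaker effect of the compound at the concentration tested), and a fourth awaits its result. Compound 1 `COc1ccc(-c2cc(/C=C/C(=O)c3ccc(N)cc3)[nH]n2)cc1` gives -37% in this assay. Compound 3 `COc1ccc(-c2cc(/C=C/C(=O)c3ccc(N)cc3)[nH]n2)cc1OC` is the same molecule with one change, (methoxy in place of hydrogen on an aromatic carbon), and in this assay compound 3 gives -91%. That single change produced the step of a number 54 percentage points lower from compound 1 to compound 3 (beyond the scatter). Compound 2 `COc1ccc(C(=O)/C=C/c2cc(-c3cc(OC)c(OC)c(OC)c3)n[nH]2)cc1OC` is built on a different core; the difference between the two cores is not broken down here. In this assay compound 2 gives -88%, which sits within the usual scatter of the number for compound 3, while its gap to compound 1 lies beyond the scatter.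

Compound 4 `COc1cc(C(=O)/C=C/c2cc(-c3cc(OC)c(OC)c(OC)c3)n[nH]2)cc(OC)c1OC` is derived from compound 2 by the same kind of change that led from compound 1 to compound 3: methoxy in place of hydrogen on an aromatic carbon. The surroundings are not identical, since in compound 4 the new group also stands meta to a methoxy group. How far compound 4 will move is expected to be small, because compound 2 already gives -88% and compound 3, carrying the same group, gives -91%, so there is little room left for a further large drop. For compound 4 the step from compound 2 is estimated as a number 2 percentage points lower from compound 2 to compound 4 (within the scatter). Compound 4 is therefore expected to give about -90% in this assay, most likely between -100% and -75%.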

Compound 4, a percentage reported as activity, at one concentration (the size of the read-out at that concentration, not a potency): -96%
Estimate against measurement, compound 4: 6 percentage points above; the measured number falls inside the stated range.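

On the other core, the same change of methoxy in place of hydrogen on an aromatic carbon gives a number 8 percentage points lower from compound 2 to compound 4 (within the scatter) in this assay, and compound 2 and compound 4 cannot be told apart in this read-out. The large step seen on the first core therefore did not carry over at the same size to the second: the same change on two cores in this assay, a number 54 percentage points lower (beyond the scatter) from compound 1 to compound 3 and a number 8 percentage points lower (within the scatter) from compound 2 to compound 4, 46 percentage points apart, beyond the scatter of two such steps

This does not show why the two steps differ, nor that methoxy does nothing on the second core. The read-out comes from a single concentration and is not a potency, compound 2 already gives -88% before the change, and in compound 4 the new group stands ortho to a methoxy group, so two pairs cannot separate these features of the surroundings from the core itself.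

The compounds shown leave open whether the difference between the cores would hold for other groups in the same place, such as an ethoxy group, a hydroxyl group or a chlorine atom. They also leave open how compound 2 and compound 4 would compare at lower concentrations, where a difference between them might or might not appear.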